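This account rests on a few compounds, and the source may have more. Where it says the series, first, only, none or still open, it means among the compounds named here.

Working notes on the series. Within the data shown here, compound 1 `Cn1nc2c(=O)n(CC3(O)CCN(Cc4ccc(-n5ccnc5)cc4Cl)CC3)cnc2c1-c1ccc(CN)cc1` in an assay on isolated protein for inhibition of ubiquitin carboxyl-terminal hydrolase 7 (Homo sapiens), with stated times of 30 min and 2 h (a higher number here means a weaker inhibitor, a lower number a stronger inhibitor), gives 228 nM, the highest number of the three measured so far. Compound 2 `Cn1nc2c(=O)n(CC3(O)CCN(Cc4ccc(-c5ccco5)cc4Cl)CC3)cnc2c1-c1ccc(OC(F)F)cc1` gives 179 nM, and compound 3 `Cn1nc2c(=O)n(CC3(O)CCN(Cc4ccc(-c5ccco5)cc4Cl)CC3)cnc2c1-c1ccc(C(=N)N)cc1` gives 87.5 nM. Among the measured compounds shown here, the only single-point step in hand is a 2.0-fold lower number from compound 2 to compound 3 (0.31 log units; beyond the scatter), and it concerns the aryl on the shared core, not the chlorophenyl side. For the measured compounds named here, compound 1 and compound 2 differ in two places at once, so their values show only that the pair lies within the scatter of each other.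

Compound 4 `Cn1nc2c(=O)n(CC3(O)CCN(Cc4ccc(-c5ccc(C(=O)O)o5)cc4Cl)CC3)cnc2c1-c1ccc(CN)cc1` is the next entry: 5-carboxyfuran-2-yl in place of 1H-imidazol-1-yl on an aromatic carbon. Going by the values given here, no measured pair isolates a change at this position, so the step from the 1H-imidazol-1-yl to the 5-carboxyfuran-2-yl has no direct precedent here; the closest hint is that compound 1 and compound 2 carry different groups on that carbon and still land close together. The expected step is therefore a 1.3-fold lower number from compound 1 to compound 4 (0.10 log units; within the scatter), small and likely within the scatter. Compound 4 is estimated at 180 nM, with a range from 80 nM to 400 nM.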

Compound 4, half-maximal inhibitory concentration: 753 nM
Beside the measured number, compound 4's estimate is 4.2-fold (0.62 log units) below it, and the stated range ends below it.
By their numbers in this assay, from the lowest: compound 3; then compounds 2 and 1 (each within the scatter of the next); then compound 4.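

In this assay, the carbon para to a large group and meta to a chloro group proves sensitive to the group it carries: 5-carboxyfuran-2-yl in place of 1H-imidazol-1-yl gives a 3.3-fold higher number from compound 1 to compound 4 (0.52 log units; beyond the scatter), with the rest of the structure unchanged. Among these compounds, this is the first reading that isolates this carbon, since the earlier single-point step concerned only the aryl on the shared core. Nothing on hand accounts for the size or direction of this step.

Going by these compounds, the change replaces the ring and introduces the carboxylic acid together, so the share of each in the step remains open. A methyl ester or a primary carboxamide at the same furan carbon, set against the unsubstituted furan-2-yl on the core of compound 1, would separate the two.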